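Cyano in place of bromo: estimate for compound 4

The source may hold more compounds than are shown below. What is called first, only, known or untested is meant among the compounds shown, and "the series" means these compounds.

Compound 1 `CC(C(=O)NCc1ccc(C(C)(C)C)cc1)c1ccc(NS(C)(=O)=O)c(Cl)c1` gives 29.5 nM in a functional assay on CHO cells for antagonist activity at transient receptor potential cation channel subfamily V member 1 (Rattus norvegicus), read by fluorescence, with a stated time of 1 h; on this read-out lower numbers stand for stronger inhibition and higher numbers for weaker inhibition. Compound 2 `CC(C(=O)NCc1ccc(C(C)(C)C)cc1)c1ccc(NS(C)(=O)=O)c(Br)c1` gives 25 nM, the second highest of the three numbers; compound 3 `CC(C(=O)NCc1ccc(C(C)(C)C)cc1)c1cc(F)c(NS(C)(=O)=O)c(F)c1` gives 7.4 nM, and the gap from compound 2 to compound 3 lies beyond the scatter. For the measured compounds named here, the only single-change step measured, a 1.2-fold lower number from compound 1 to compound 2 (0.07 log units; within the scatter), lies within the scatter. Compound 4 `CC(C(=O)NCc1ccc(C(C)(C)C)cc1)c1ccc(NS(C)(=O)=O)c(C#N)c1` differs from compound 2 by cyano in place of bromo on an aromatic carbon. Going by the values given here, no measured step replaces a halogen with cyano, so the bromo-for-chloro step is the nearest comparison, and it stayed within the scatter; for compound 4 no step beyond the scatter is therefore expected in this assay. Compound 4 is thus estimated at 25 nM, with a range from 8 nM to 75 nM. This means an expected step of no change at the digits printed from compound 2 to compound 4 (within the scatter).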

Compound 4, inhibition constant: 467 nM
Compound 4: the middle estimate sits 19-fold (1.27 log units) below what was measured; measured number outside the range, above it.
By their numbers in this assay, from the lowest: compound 3; then compounds 2 and 1 (each within the scatter of the next); then compound 4.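

At this position, ortho to a methanesulfonamido group, exchanging one halogen for the other left the number within the scatter, but the position is not indifferent to every replacement. In this assay, cyano in place of bromo gives a 19-fold higher number from compound 2 to compound 4 (1.27 log units; beyond the scatter) and cyano in place of chloro gives a 16-fold higher number from compound 1 to compound 4 (1.20 log units; beyond the scatter) on the same core. Nothing available accounts for these large steps.

Going by these compounds, whether a methyl, methoxy or amino group here would read like the halogens or like cyano remains open. A single cyano compound also cannot show whether the same change would behave alike on another core.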